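The source may report more compounds than this note shows. Statements on the series, on what has been measured and on what is new or still open speak of the compounds shown alone.

The study brings together two measured compounds and one that awaits a number. Compound 1 `COc1cc2c(/C=C3/C(=O)Nc4ccc(Cl)cc43)c(Cl)n(Cc3cc(OC)c(OC)c(OC)c3)c2cc1C` and compound 2 `COc1c(/C=C2/C(=O)Nc3ccccc32)c2ccccc2n1-c1ccccc1` were both examined in a functional assay on cells (Melanoma cell, Homo sapiens) for cytotoxicity, with a stated time of 48 h; a lower number here means a stronger inhibitor of growth, a higher number a weaker inhibitor of growth. In this assay compound 1 gives 2290 nM, and compound 2 gives 1480 nM. The two numbers lie within the usual scatter of each other, so neither compound can be said to inhibit growth more strongly than the other on this evidence. The next compound, compound 3 `COc1ccc2c(c1)/C(=C\c1c(OC)n(-c3ccccc3)c3ccccc13)C(=O)N2`, differs from compound 2 in one place: methoxy in place of hydrogen on an aromatic carbon. No comparable single change between measured compounds is available here, so there is nothing in the data to argue for a shift beyond the scatter in either direction. Compound 3 is therefore expected to give about 1500 nM, somewhere between 600 nM and 4000 nM. The step from compound 2 to compound 3 is estimated at a 1.0-fold higher number from compound 2 to compound 3 (0.01 log units; within the scatter).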

Compound 3, concentration for 50% growth inhibition: 2400 nM
Beside the measured number, compound 3's estimate is 1.6-fold (0.20 log units) below it; low and high end bracket the measured number.
By their numbers in this assay, from the lowest: compounds 2, 1 and 3 (each within the scatter of the next).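

In this assay, methoxy in place of hydrogen on an aromatic carbon gives a 1.6-fold higher number from compound 2 to compound 3 (0.21 log units; within the scatter) and provides the first single-place comparison among these compounds. At this carbon, on the six-membered aromatic ring of carbon only, meta to a fused ring and para to a fused ring, adding methoxy therefore produces no shift that can be told from the scatter. No independent measurement bears on this result.

On these data alone, whether an amine or a carboxylic acid on this same carbon would move the number beyond the scatter remains open. So does whether methoxy would behave in the same way on another carbon of this ring, since a single step describes one position and one group only.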